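The source may report more compounds than this note shows. Statements on the series, on what has been measured and on what is new or still open speak of the compounds shown alone.

Compound 1, `CN(C)c1ccc(C(=O)Nc2cccc(NC(=O)COc3ccc4c(c3)OCCC4=O)c2)cc1`: in an assay on isolated protein for inhibition of Rho-associated protein kinase 2 (Homo sapiens), read by scintillation counting, radiometric assay and 33P incorporation, with a stated time of 40 min, in the presence of a further agent that is not named here (a lower number here means a stronger inhibitor, a higher number a weaker inhibitor), compound 1 gives 85 nM.
Compound 2, `CN(C)c1ccc(C(=O)Nc2cccc(NC(=O)COc3ccc4occc(=O)c4c3)c2)cc1`: compound 2 reaches only the limit > 10000 nM, a bound of this assay and not a number.
Compound 3, `O=C(COc1ccc2c(=O)ccoc2c1)Nc1cccc(NC(=O)c2ccccc2)c1`: compound 3 gives 16 nM.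

Compound 3 holds the lowest of the two numbers; the nearest is compound 1, which sits higher by a margin beyond the scatter. Going by the values given here, the one step between measured compounds, an at least 110-fold higher number from compound 1 to compound 2 (2.07 log units; beyond the scatter), ends at a limit of > 10000 nM in this assay, at which 1 of the 3 values shown sits, and concerns a different part of the molecule, so it does not bear on the change studied here. Compound 4, `O=C(COc1ccc2c(=O)ccoc2c1)Nc1cccc(NC(=O)c2ccc(C(=O)O)cc2)c1`, differs from compound 3 by carboxy in place of hydrogen on an aromatic carbon. Among the compounds with values here, with no measured step covering this change, only a modest shift is expected; the estimated step is a 2.2-fold higher number from compound 3 to compound 4 (0.34 log units; beyond the scatter). Compound 4 is expected to give 35 nM, from 8 nM to 160 nM.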

Compound 4, half-maximal inhibitory concentration: 2030 nM
Beside the measured number, compound 4's estimate is 58-fold (1.76 log units) below it, outside the stated range (above it).
By their numbers in this assay, from the lowest: compound 3; then compound 1; then compound 4. At a limit, above all of these: compound 2.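

Going by these compounds alone, the ring position para to a large group proves sensitive, which the earlier compounds could not show, as none of their steps touched it: carboxy in place of hydrogen gives a 130-fold higher number from compound 3 to compound 4 (2.10 log units; beyond the scatter) in this assay. Compound 4 still gives a measurable number, not a limit. Nothing measured here explains this loss.

On these data alone, whether any group at this position is poorly accepted, or carboxy specifically, remains open. A methyl ester or an aminomethyl group in the same place would help separate these two readings.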